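A few compounds are considered here, and "the series" means these few. Any claim that something is new, unique, unknown or untested is made for them only; others in the source may bear on it.

Compound 1 `COc1cccc(/C=C2\CCC/C(=C\c3ccccc3Br)C2=O)c1OC` and compound 2 `COc1cccc(/C=C2\CCC/C(=C\c3cccc(Br)c3)C2=O)c1OC` share a core, as do compound 3 `COc1ccc(/C=C2\CCC/C(=C\c3ccccc3Br)C2=O)cc1OC` and compound 4 `COc1ccc(/C=C2\CCC/C(=C\c3cccc(Br)c3)C2=O)cc1OC`; the difference between the two cores is not broken down here. In an ADME assay on NHDF cells (Homo sapiens) for cytotoxicity, read by MTT assay, with a stated time of 72 h (a higher number here means a weaker inhibitor, a lower number a stronger inhibitor), compound 1 gives only a limit, > 50000 nM, as noted in the limit of > 50000 nM in this assay, at which 1 of the 3 values shown sits. In this assay compound 2 gives 23900 nM. The change between them, (3-bromophenyl in place of 2-bromophenyl on a double-bonded chain carbon bound to a double-bonded ring carbon), brought an at least 2.0-fold lower number from compound 1 to compound 2 (0.32 log units; beyond the scatter). In this assay compound 3 gives 21800 nM, which lies within the scatter of compound 2. Compound 4 differs from compound 3 by the same change, (3-bromophenyl in place of 2-bromophenyl on a double-bonded chain carbon bound to a double-bonded ring carbon). Because the measured pair showed an at least 2.0-fold lower number from compound 1 to compound 2 (0.32 log units; beyond the scatter) only as a bound set by the limit of compound 1, the true size of that step is open, and the expected step of a 1.8-fold lower number from compound 3 to compound 4 (0.26 log units; within the scatter) is taken as of similar or modest size. Compound 4 is therefore estimated at 12000 nM in this assay, with a range from 5000 nM to 30000 nM expected to hold most repeat readings.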

Compound 4, half-maximal inhibitory concentration: 12400 nM
The estimate for compound 4 lay 1.0-fold (0.01 log units) below the measured number; the measured number falls inside the stated range.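

In this assay, putting 3-bromophenyl in place of 2-bromophenyl gave a 1.8-fold lower number from compound 3 to compound 4 (0.25 log units; within the scatter), so on this core the step does not separate the two compounds beyond the usual variation between repeats. Set beside the earlier step, the number falls on both cores, but only the first step lies beyond the scatter, and that step is a bound rather than a measured size: the same change on two cores in this assay, an at least 2.0-fold lower number (0.32 log units; beyond the scatter) from compound 1 to compound 2 and a 1.8-fold lower number (0.25 log units; within the scatter) from compound 3 to compound 4; the limit leaves it open whether they differ. The two pairs therefore share a direction, but they show neither that the size of the step carries over from one core to the other nor that it differs between them.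

The compounds shown leave open whether the same direction would hold in this assay if a chlorine atom or a methyl group took the place of the bromine. Going by these compounds, it also remains open how the series would read in this assay with an amine or a carboxylic acid on that phenyl ring.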